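Aryloxymethyl ketone series: fluorinated phenoxy variation

The compounds below may be only part of what the source reports. "The series", "measured", "known", "first", "only" and "open" are said of these compounds alone.

Compound 1 `CC(C)[C@H](NC(=O)COc1cccc2ccccc12)C(=O)N[C@@H](CC(=O)O)C(=O)COc1ccc(C#N)cc1`; in a functional assay on Jurkat cells (Homo sapiens) (a higher number here means a weaker inhibitor, a lower number a stronger inhibitor), compound 1 gives > 100000 nM, which is a limit of the assay rather than a number.
Compound 2 `CC(C)[C@H](NC(=O)COc1cccc2ccccc12)C(=O)N[C@@H](CC(=O)O)C(=O)COc1ccc(F)cc1F`; in this assay compound 2 gives 33200 nM.

Going by the values given here, compound 2 holds the only numerical value in this assay; the other entry is a limit (the limit of > 100000 nM in this assay, at which 1 of the 2 values shown sits). Among the compounds with values here, the single measured step, an at least 3.0-fold lower number from compound 1 to compound 2 (0.47 log units; beyond the scatter), covers the change from 4-cyanophenyl to 2,4-difluorophenyl on an oxygen on a saturated carbon and shows that varying the aryl group on this oxygen can move the number beyond the scatter.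

Compound 3 `CC(C)[C@H](NC(=O)COc1cccc2ccccc12)C(=O)N[C@@H](CC(=O)O)C(=O)COc1cccc(C(F)(F)F)c1F` differs from compound 2 by 2-fluoro-3-(trifluoromethyl)phenyl in place of 2,4-difluorophenyl on an oxygen on a saturated carbon. Within the data shown here, the change keeps a fluorinated phenyl on the same oxygen on a saturated carbon, but no measured step covers a trifluoromethyl group there, so the direction cannot be read from the data. The step of a 1.3-fold lower number from compound 2 to compound 3 (0.12 log units; within the scatter) is expected to stay within the scatter of compound 2. For compound 3 in this assay the estimate is 25000 nM, with a range from 8000 nM to 80000 nM.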

Compound 3, half-maximal inhibitory concentration: 50400 nM
The estimate for compound 3 lay 2.0-fold (0.30 log units) below the measured number, within the range that was stated.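

In this assay, the change from 2,4-difluorophenyl to 2-fluoro-3-(trifluoromethyl)phenyl on this oxygen gives a 1.5-fold higher number from compound 2 to compound 3 (0.18 log units; within the scatter), so compound 2 and compound 3 cannot be told apart, although the group grows from 8 to 11 heavy atoms and from 2 to 4 fluorines. At this position, two different fluorinated phenyl groups therefore give numbers within the scatter of each other. The change from 4-cyanophenyl reads as an at least 1.9-fold lower number from compound 1 to compound 3 (0.29 log units; that floor lies within the scatter), which is only a floor, so the separation from compound 1 seen with 2,4-difluorophenyl is not shown beyond the scatter for this group, as one end of the step is a limit: the limit of > 100000 nM in this assay, at which 1 of the 3 values shown sits.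

The step from compound 2 to compound 3 alters the ring at more than one point, so the effect of adding the trifluoromethyl group cannot be separated from that of losing the 4-fluorine. On these data alone, it also remains open whether a phenyl carrying an amine or a carboxylic acid, or a plain alkyl chain on this oxygen, would take the number clearly away from that of compound 2.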